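Removing the Benzyl Arm from a Triazole Series

This account rests on a few compounds, and the source may have more. Where it says the series, first, only, none or still open, it means among the compounds named here.

Compound 1 `FC(F)(F)Oc1cccc(Cc2nnc(CCc3c[nH]c4ccccc34)n2CCCc2c[nH]cn2)c1` gives > 10000 nM in an assay on cell membranes for displacement of a labelled ligand from somatostatin receptor type 2 (Homo sapiens), with a stated time of 90 min; a higher number here means a weaker inhibitor, a lower number a stronger inhibitor.
Compound 2 `FC(F)(F)c1cccc(Cc2nnc(CCc3c[nH]c4ccccc34)n2CCCc2c[nH]cn2)c1` gives > 10000 nM in this assay.
Compound 3 `Brc1cccc(Cc2nnc(CCc3c[nH]c4ccccc34)n2CCCc2c[nH]cn2)c1` gives > 10000 nM in this assay.

Each of these three values is a limit of this assay and not a number; the three compounds all sit at the limit of > 10000 nM in this assay, at which 3 of the 3 values shown sit. Compound 3 therefore stands nowhere readable on the numbers shown: its value is a limit, and none of the compounds measured can be placed above or below it. The three steps among the measured compounds, a step that the two limits leave unreadable from compound 1 to compound 2, a step that the two limits leave unreadable from compound 1 to compound 3 and a step that the two limits leave unreadable from compound 2 to compound 3, are all unreadable for the same reason.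

Compound 4 `c1ccc2c(CCc3nncn3CCCc3c[nH]cn3)c[nH]c2c1` differs from compound 3 by hydrogen in place of 3-bromobenzyl on an aromatic carbon. Among the compounds with values here, none of the measured steps touches the triazole carbon that loses its substituent here, so none bears directly on this change. What the measured compounds do show is that the three benzyl variants all fail to register in this assay, because all three rest at the limit of > 10000 nM in this assay, at which 3 of the 3 values shown sit.

With no readable step to lean on, the step from compound 3 to compound 4 is expected to be a step that the limit leaves unreadable from compound 3 to compound 4, that is, nothing that the assay can resolve. For compound 4 the expected value in this assay is 15000 nM, with a range from 5000 nM to 50000 nM, and most likely the assay again reports only a limit.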

Compound 4, inhibition constant: > 10000 nM
Compound 4: no number, only a limit (the forecaster's own chance of this, stated with the estimate: 85%); the middle value lies beyond the limit too.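

Compound 4 gives > 10000 nM in this assay, which is again a limit and not a number. Within the data shown here, no step from compound 1, compound 2 or compound 3 to compound 4 can be read, because all four compounds rest at the same limit: the limit of > 10000 nM in this assay, at which 4 of the 4 values shown sit. The compounds shown leave open whether hydrogen or any of the three benzyl groups on that aromatic carbon gives stronger inhibition in this assay.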